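This account rests on a few compounds, and the source may have more. Where it says the series, first, only, none or still open, it means among the compounds named here.

Series notes. Compound 1 `CCCCc1oc2ccccc2c1C(=O)c1ccc(OCC(=O)N2CCCC2)cc1` and compound 2 `CCCCc1oc2ccccc2c1C(=O)c1ccc(OCC(=O)N[C@@H](C)c2ccccc2)cc1` share one core and differ only at the amide on the carbonyl carbon. In a functional assay on HL-60 cells (Homo sapiens) for antiproliferative activity, read by MTT assay, with a stated time of 24 h (on this read-out higher numbers stand for weaker inhibition and lower numbers for stronger inhibition), compound 1 gives > 50000 nM, which is a limit of the assay and not a number. In this assay compound 2 gives > 50000 nM, again only a limit. The step that the two limits leave unreadable from compound 1 to compound 2 is thus unreadable in size and direction. Compound 2 stands where compound 1 stands, at the limit of > 50000 nM in this assay, at which 2 of the 2 values shown sit, so no number yet separates the pair.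

Compound 3 `CCCCc1oc2ccccc2c1C(=O)c1ccc(OCCCC(=O)N2CCCCC2)cc1` is not yet measured. Its change from compound 2 is 2-((piperidin-1-yl)carbonyl)ethyl in place of (1-phenylethyl)carbamoyl on a saturated chain carbon bound to an oxygen on an aromatic ring. Among the compounds with values here, the one measured step, a step that the two limits leave unreadable from compound 1 to compound 2, touches the same amide end of the chain but gives no readable size, so no direction can be taken from it. Compound 3 is expected to sit at about 60000 nM, within 20000 nM to 200000 nM, most likely again reported only as a limit. The step that the limit leaves unreadable from compound 2 to compound 3 is expected to stay within the scatter.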

Compound 3, half-maximal inhibitory concentration: 31900 nM
Beside the measured number, compound 3's estimate is 1.9-fold (0.27 log units) above it; measured number inside the range.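

In this assay, within the data shown here, compound 3 is the only one of the three compounds to give a number and not a limit, so this saturated chain carbon bound to an oxygen on an aromatic ring now has one readable value. The change to 2-((piperidin-1-yl)carbonyl)ethyl gives an at least 1.5-fold lower number from compound 2 to compound 3 (0.19 log units; that floor lies within the scatter), and the same group in place of (pyrrolidin-1-yl)carbonyl gives an at least 1.5-fold lower number from compound 1 to compound 3 (0.19 log units; that floor lies within the scatter). Both steps are floors, so their true size is not known, and the step between the other two compounds cannot be read: the limit of > 50000 nM in this assay, at which 2 of the 3 values shown sit.

The compounds shown do not separate the longer chain from the piperidine ring, as 2-((piperidin-1-yl)carbonyl)ethyl differs from (pyrrolidin-1-yl)carbonyl in both. Also open, going by these compounds, is how the number responds to a still longer chain, or to a carboxylic acid or an amine in place of the amide at the chain end.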